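The compounds below may be only part of what the source reports. "The series", "measured", "known", "first", "only" and "open" are said of these compounds alone.

Measured compounds in a functional assay on MCF7 cells (Homo sapiens) for cytotoxicity, read by MTT assay, with a stated time of 72 h; on this read-out higher numbers stand for weaker inhibition and lower numbers for stronger inhibition:
- compound 1 `Cc1ccnc(/C(N)=N/NC(=S)N2CCSCC2)c1`: 6900 nM
- compound 2 `N/C(=N\NC(=S)N1CCSCC1)c1ccccn1`: 8800 nM

For the measured compounds named here, compound 2 stands at the higher of the two numbers, but its only neighbour is close: a 1.3-fold higher number from compound 1 to compound 2 (0.11 log units; within the scatter). Compound 3 `Cc1cccc(/C(N)=N/NC(=S)N2CCSCC2)n1` is made from compound 2 by methyl in place of hydrogen on an aromatic carbon, the methyl now sitting next to the ring nitrogen. Going by the values given here, the one step that bears on this, a 1.3-fold higher number from compound 1 to compound 2 (0.11 log units; within the scatter), shows a methyl on the same ring changing the number by nothing beyond the scatter. No step beyond the scatter is therefore expected here either: a 1.1-fold lower number from compound 2 to compound 3 (0.04 log units; within the scatter). Compound 3 is estimated at 8000 nM, with a range of 4000 nM to 16000 nM.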

Compound 3, half-maximal inhibitory concentration: > 100000 nM
Compound 3: no number, only a limit; the forecaster's own chance of this, stated with the estimate: 5%; middle value at least 12-fold (1.09 log units) away from the limit.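

Methyl in place of hydrogen next to the ring nitrogen is a large step in this assay: an at least 11-fold higher number from compound 2 to compound 3 (1.05 log units; beyond the scatter). The same exchange therefore does not act alike at every place on this ring, since the step involving the methyl of compound 1 stays small: a 1.3-fold higher number from compound 1 to compound 2 (0.11 log units; within the scatter). The entry for compound 3 is a limit of the assay, not a number: the limit of > 100000 nM in this assay, at which 1 of the 3 values shown sits.

As far as these compounds go, whether an ethyl, a methoxy or an amine next to the ring nitrogen behaves as methyl does remains open. The compounds shown give no cause for the step.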